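The source may hold more compounds than are shown below. What is called first, only, known or untested is meant among the compounds shown, and "the series" means these compounds.

Compound 1 `COc1ccccc1OCCNc1ccc(=O)n(Cc2ccc(OC)c(OC3CCCC3)c2)n1` in a functional assay on K562 cells (Homo sapiens) for antiproliferative activity, read by MTT assay, with a stated time of 48 h (on this read-out higher numbers stand for weaker inhibition of growth and lower numbers for stronger inhibition of growth), gives 28000 nM.
Compound 2 `COc1ccccc1OCCNc1ccc(=O)n(Cc2ccc(OC(F)F)c(OC3CCCC3)c2)n1` gives 9100 nM.
Compound 3 `COc1ccccc1OCCNc1cnn(Cc2ccc(OC(F)F)c(OC3CCCC3)c2)c(=O)c1Cl` gives > 100000 nM, which is a limit of the assay rather than a number (the limit of > 100000 nM in this assay, at which 1 of the 3 values shown sits).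

Compound 1 differs from compound 2 by methyl in place of difluoromethyl on an oxygen on an aromatic ring, and this change gave a 3.1-fold higher number from compound 2 to compound 1 (0.49 log units; beyond the scatter). How the core of compound 3 differs from the core of compound 2 is not broken down here. Compound 4 `COc1ccccc1OCCNc1cnn(Cc2ccc(OC)c(OC3CCCC3)c2)c(=O)c1Cl` has not yet been measured; it differs from compound 3 by methyl in place of difluoromethyl on an oxygen on an aromatic ring, the same change as that from compound 2 to compound 1, made at the same kind of place. Since compound 3 already sits at the limit (the limit of > 100000 nM in this assay, at which 1 of the 3 values shown sits), compound 4 is expected to give a weak or unmeasurable result as well, with an expected step that the limit leaves unreadable from compound 3 to compound 4. Compound 4 is estimated at 250000 nM, between 70000 nM and 1000000 nM.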

Compound 4, concentration for 50% growth inhibition: > 100000 nM
Compound 4: a limit, no number (the forecaster's own chance of this, stated with the estimate: 80%); the middle value does not contradict the limit.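

Among these compounds, compound 3 and compound 4 both sit at a limit of this assay, so no step between them can be read. The compounds shown leave open whether methyl in place of difluoromethyl changes growth inhibition on this core.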